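The source may report more compounds than this note shows. Statements on the series, on what has been measured and on what is new or still open speak of the compounds shown alone.

- compound 1 `COc1ccc(/C=C/C(=O)/C=C/c2ccc(OCc3cn(CCCCOc4cc(=O)oc5ccccc45)nn3)c(OC)c2)cc1OC` gives 53% in the first measurement
- compound 2 `COc1cccc(/C=C/C(=O)/C=C/c2ccc(OCc3cn(CCCCOc4cc(=O)oc5ccccc45)nn3)c(OC)c2)c1` gives 46% in the second measurement

For the measured compounds named here, in a functional assay on COLO 205 cells (Homo sapiens) for inhibition, read by sulforhodamine B assay, with a stated time of 48 h, tested at 50 uM (on this read-out lower numbers stand for less inhibition of growth and higher numbers for more inhibition of growth at the one concentration tested), compound 2 gives 46% and lies within the scatter of compound 1, the only other measured compound. Compound 3 `COc1cc(/C=C/C(=O)/C=C/c2ccccc2)ccc1OCc1cn(CCCCOc2cc(=O)oc3ccccc23)nn1` differs from compound 2 by hydrogen in place of methoxy on an aromatic carbon (hydrogen in place of methoxy on an aromatic carbon, 3-methoxyphenyl to phenyl). One measured step is of this kind (a number 7 percentage points lower from compound 1 to compound 2 (within the scatter)), so no change beyond the scatter is expected in this assay. The estimated step is a number 4 percentage points lower from compound 2 to compound 3 (within the scatter) and would be of similar size. Compound 3 is expected at 42% (estimated range 30% to 54%).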

Compound 3, percent growth inhibition at one concentration: 31%
Compound 3: the middle estimate sits 11 percentage points above what was measured; the measured number falls inside the stated range.
By their numbers in this assay, from the lowest: compound 3; then compounds 2 and 1 (each within the scatter of the next).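

In this assay, for the compounds shown here, replacing the methoxy on the 3-methoxyphenyl group with hydrogen gives a number 15 percentage points lower from compound 2 to compound 3 (beyond the scatter), the first step of this kind to pass beyond the scatter. Going from 3,4-dimethoxyphenyl to phenyl gives a number 22 percentage points lower from compound 1 to compound 3 (beyond the scatter), so the unsubstituted phenyl separates from both methoxy-bearing compounds, while the step of a number 7 percentage points lower from compound 1 to compound 2 (within the scatter) does not separate those two from each other. No evidence at hand accounts for this drop. The compounds shown leave open whether a hydroxy group, a fluorine atom or a dimethylamino group on this ring would give a number like that of compound 1 or like that of compound 3.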